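Swapping One Side Group on the Only Numbered Compound

A few compounds are considered here, and "the series" means these few. Any claim that something is new, unique, unknown or untested is made for them only; others in the source may bear on it.

In a functional assay on MV4-11 cells (Homo sapiens) for antiproliferative activity, read by CellTiter-Glo, with a stated time of 72 h (on this read-out lower numbers stand for stronger inhibition of growth and higher numbers for weaker inhibition of growth), compound 1 `COCCNc1cc(-c2csc(NCC3CCOCC3)n2)c(Cl)cn1` gives > 10000 nM, which is a limit and not a number. Compound 2 `Clc1cnc(Nc2ccccc2)cc1-c1csc(NCC2CCOCC2)n1` gives > 10000 nM, which is also a limit. Within the data shown here, compound 3 `COCCN[C@H]1CC[C@H](Nc2cc(-c3csc(OCC4CCOCC4)n3)c(Cl)cn2)CC1` gives 570 nM, the only true number so far. The rest of the picture is a ceiling: the limit of > 10000 nM in this assay, at which 2 of the 3 values shown sit.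

Compound 4 `COCCN[C@H]1CC[C@H](Nc2cc(-c3csc(NCc4ccccc4)n3)c(Cl)cn2)CC1` differs from compound 3 in one place. It has benzylamino in place of (oxan-4-yl)methoxy on an aromatic carbon of a five-membered aromatic ring with 1 nitrogen and 1 sulfur (benzylamino in place of (oxan-4-yl)methoxy on an aromatic carbon).

Among the measured compounds shown here, only one measured step exists, a step that the two limits leave unreadable from compound 1 to compound 2. It concerns a different part of the molecule and has no readable size, so it offers no guide to this swap. For the measured compounds named here, no measured pair tests this change directly. With compound 3 at 570 nM as the only anchor, no step beyond the scatter is expected in this assay, and no direction can be favoured. The expected change is a 1.6-fold lower number from compound 3 to compound 4 (0.21 log units; within the scatter), an estimate that stays within the usual scatter. With so little evidence, the range must be wide. For compound 4 the estimated value is 350 nM, with an expected range from 60 nM to 2500 nM.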

Compound 4, concentration for 50% growth inhibition: 330 nM
The estimate for compound 4 lay 1.1-fold (0.03 log units) above the measured number, and the stated range covers the measured number.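

In this assay, benzylamino in place of (oxan-4-yl)methoxy gives a 1.7-fold lower number from compound 3 to compound 4 (0.24 log units; within the scatter) and so this pair does not separate the two groups. Among these compounds, this is the first readable step at this position, on an aromatic carbon of the five-membered aromatic ring with 1 nitrogen and 1 sulfur, and it shows that two rather different groups of equal heavy-atom count can sit there with no change beyond the scatter, even though the swap replaces a non-aromatic ring with an aromatic one and 0 hydrogen-bond donors with 1. Compound 4, like compound 3, gives a true number rather than a limit, unlike the other two compounds, which stay at the ceiling: the limit of > 10000 nM in this assay, at which 2 of the 4 values shown sit.

Since the linking atom and the ring change together in this single swap, the pair cannot show what each part contributes, and a partner such as the benzyloxy group or the (oxan-4-yl)methylamino group on the same carbon would separate the two. On these data alone, how far this position accepts other kinds of group also stays open, for example a small methoxy group or a benzylamino group carrying a carboxylic acid on its ring.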